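Swapping a pyridine amide for a methylphenyl amide

A few compounds are considered here, and "the series" means these few. Any claim that something is new, unique, unknown or untested is made for them only; others in the source may bear on it.

Measured compounds:
compound 1 `O=C(CN1CCN(c2ccccn2)CC1)Nc1cccnc1` — 47.3%
compound 2 `Cc1ccc(C2CCN(CC(=O)Nc3cccc(C)c3)CC2)nc1` — "not active" (no number reported)
compound 3 `O=C(CN1CCN(c2ccc(Cl)cn2)CC1)Nc1cccnc1` — "not active" (no number reported)

In a functional assay on cells for agonist activity at D(4) dopamine receptor (Homo sapiens), read by TR-FRET and cAMP accumulation, with a stated time of 30 min (on this read-out higher numbers stand for larger maximal responses and lower numbers for smaller maximal responses), compound 1 gives 47.3%, the only numerical result among the three; in this assay compound 2 gives "not active" (no number reported) and compound 3 gives "not active" (no number reported), each without a number. Compound 4 `Cc1cccc(NC(=O)CN2CCN(c3ccccn3)CC2)c1` has not yet been measured. It differs from compound 1 in one place: 3-methylphenyl in place of pyridin-3-yl on an amide-type nitrogen. Compound 2, which also carries a 3-methylphenyl on its amide nitrogen but a different core, was not active, so a downward step is expected, larger than the usual scatter. For compound 4 the estimated result in this assay is 25%, with a likely range from 0% to 50%, which means an expected step of a number 22.3 percentage points lower from compound 1 to compound 4 (beyond the scatter).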

Compound 4, largest response reached (Emax), in percent of the reference or control that the assay uses: 64.2%
For compound 4 the middle estimate is 39.2 percentage points below the measured one; measured number above the stated range.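

In this assay, placing 3-methylphenyl instead of pyridin-3-yl on the amide nitrogen gives a number 16.9 percentage points higher from compound 1 to compound 4 (beyond the scatter). On this core, then, a response does not depend on the ring nitrogen of pyridin-3-yl, and an all-carbon ring with a methyl group is accepted at this position. The change removes that ring nitrogen and adds the methyl group in one step, so a plain phenyl ring would be needed to separate their contributions. Nothing available explains why the response rises.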